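The compounds below may be only part of what the source reports. "The series", "measured", "known", "first", "only" and "open" are said of these compounds alone.

The measured compounds, with their results in a functional assay on MCF7 cells (Homo sapiens) for cytotoxicity, read by MTT assay, with a stated time of 72 h; a higher number here means a weaker inhibitor, a lower number a stronger inhibitor:
- compound 1, `CCN(CC)CCCOc1c(OCc2ccccc2)cc(O)c2c(=O)cc(-c3ccccc3)oc12`, gives 3210 nM
- compound 2, `CN1CCN(CCCOc2c(OCc3ccccc3)cc(O)c3c(=O)cc(-c4ccccc4)oc23)CC1`, gives 1020 nM
- compound 3, `CN1CCN(CCCCOc2c(OCc3ccc(C#N)cc3)cc(O)c3c(=O)cc(-c4ccccc4)oc23)CC1`, gives 2420 nM

Among these three, compound 3 has the second highest number. Its value sits close to that of compound 1, within the usual scatter of repeated measurements, while compound 2 lies beyond the scatter in the direction of a stronger inhibitor.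

Among the measured compounds shown here, the only single change measured so far is the one from compound 1 to compound 2: a 3.1-fold lower number from compound 1 to compound 2 (0.50 log units; beyond the scatter). That change sits at the far end of the chain, away from the part of the molecule that differs between compound 3 and compound 4.

Compound 4 is `CN1CCN(CCCCOc2c(OCc3cccs3)cc(O)c3c(=O)cc(-c4ccccc4)oc23)CC1`. It differs from compound 3 in one place: thiophen-2-yl in place of 4-cyanophenyl on a saturated chain carbon bound to an oxygen on an aromatic ring. For the measured compounds named here, no measured pair in this set differs in the same way, so there is nothing in the data that points to a direction for this change. Compounds 2 and 3 differ from each other in two places at once, and their values show a gap beyond the scatter, but that gap cannot be assigned to either place alone.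

Going by the values given here, with no comparable step to draw on, the expectation is a change no larger than the scatter: a 1.0-fold lower number from compound 3 to compound 4 (0.00 log units; within the scatter). In this assay compound 4 is therefore estimated at 2400 nM, within a range from 900 nM to 6500 nM.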

Compound 4, half-maximal inhibitory concentration: 3180 nM
Compound 4: the middle estimate sits 1.3-fold (0.12 log units) below what was measured, within the range that was stated.
By their numbers in this assay, from the lowest: compound 2; then compounds 3, 4 and 1 (each within the scatter of the next).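

In this assay, among the compounds shown here, the swap at this position gives a 1.3-fold higher number from compound 3 to compound 4 (0.12 log units; within the scatter), which lies within the scatter and is the first reading of a change on this side of the molecule. The exchange is a substantial one in structural terms: the 4-cyanophenyl group, with 8 heavy atoms, a six-membered carbon ring and a nitrile, gives way to thiophen-2-yl, with 5 heavy atoms and a five-membered ring containing sulfur, yet this pair shows no difference beyond the scatter in this cell assay. No separate measurement in hand bears on this result, so it stands as an observation without an explanation.

Two aromatic groups alone cannot show whether this position tolerates change in general, and a group of another kind here, such as a 4-carboxyphenyl or a 4-aminophenyl ring, could still give a different result. Going by these compounds, it also remains open how much of the gap between compound 2 and compound 3 comes from each of the two places where they differ.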